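Ester variation in a dihydropyrimidinone series: compound 4

The source may report more compounds than this note shows. Statements on the series, on what has been measured and on what is new or still open speak of the compounds shown alone.

Compound 2 `CC1=C(C(=O)OC(C)(C)C)C(c2ccsc2)NC(=O)N1` gives 1% in an assay on membranes from HeLa cells for displacement of a labelled ligand from adenosine receptor A3 (Homo sapiens), read by scintillation counting, with a stated time of 180 min, tested at 1 uM (on this read-out lower numbers stand for less inhibition and higher numbers for more inhibition at the one concentration tested (going by the name of the read-out)), the lowest of the three numbers; compound 1 `CC1=C(C(=O)OC(C)(C)C)C(c2ccoc2)NC(=O)N1` gives 2%, a difference of a number 1 percentage points lower from compound 1 to compound 2 (within the scatter), while compound 3 `CC1=C(C(=O)OC(C)(C)C)C(c2ccsc2)NC(=O)N1C` gives 14%, the step being a number 13 percentage points higher from compound 2 to compound 3 (beyond the scatter). Compound 4 `CCC(CC)OC(=O)C1=C(C)NC(=O)NC1c1ccsc1` differs from compound 2 by pentan-3-yl in place of tert-butyl on an oxygen next to a carbonyl group, a change at the ester oxygen. Neither measured step concerns this position: one varies the aromatic ring on the saturated ring carbon, the other the ring nitrogen. Among the measured compounds shown here, with no step at the ester to draw on, and both steps at other sites small to modest, no change beyond the scatter is expected for compound 4, whose step is estimated as a number 2 percentage points higher from compound 2 to compound 4 (within the scatter). Compound 4 is therefore expected to give about 3%, within -5% to 12%.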

Compound 4, a percentage reported as inhibition, at one concentration (the size of the read-out at that concentration, not a potency): 6%
Compound 4: the middle estimate sits 3 percentage points below what was measured; measured number inside the range.
By their numbers in this assay, from the lowest: compounds 2, 1, 4 and 3 (each within the scatter of the next, the first and the last beyond it).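

Among the compounds shown here, the first step at this position, pentan-3-yl in place of tert-butyl on an oxygen next to a carbonyl group, reads as a number 5 percentage points higher from compound 2 to compound 4 (within the scatter) in this assay. This one exchange of ester groups therefore does not separate compound 4 from compound 2 on this read-out. Nothing available explains this result.

As far as these compounds go, what a benzyl ester or a free carboxylic acid would give here remains open. Also open, from the compounds shown here alone, is whether the methyl on the amide-type ring nitrogen in compound 3 would give a similar step alongside pentan-3-yl.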